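A longer chain ending in methylpiperazine

This account rests on a few compounds, and the source may have more. Where it says the series, first, only, none or still open, it means among the compounds named here.

In a functional assay on A549 cells (Homo sapiens) for cytotoxicity, read by MTT assay, with a stated time of 72 h (a lower number here means a stronger inhibitor, a higher number a weaker inhibitor), compound 1 (`O=C1c2c[n+]([O-])c3ccccc3c2C(=O)c2c1c1ccccc1n2CCCCn1ccnc1`) gives 170 nM and compound 2 (`O=C1c2c[n+]([O-])c3ccccc3c2C(=O)c2c1c1ccccc1n2CCN1CCCC1`) gives 410 nM on the shared core. Compound 3 (`O=C1c2c[n+]([O-])c3ccccc3c2C(=O)c2c1c1ccccc1n2CCCCN1CCCCC1`) gives 150 nM and so shares the low end of this small series with compound 1. Compound 4 (`CN1CCN(CCCCCCn2c3c(c4ccccc42)C(=O)c2c[n+]([O-])c4ccccc4c2C3=O)CC1`) is still unmeasured. It differs from compound 3 by one change: 2-(4-methylpiperazin-1-yl)ethyl in place of piperidin-1-yl on a saturated chain carbon, four bonds along the chain from an aromatic nitrogen at the same place. Cut one bond further out, this reads 2-(piperidin-1-yl)ethyl to 4-(4-methylpiperazin-1-yl)butyl.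

Among the measured compounds shown here, two measured steps bear on it. Exchanging one ring for another at the end of a chain of the same length gave a 1.1-fold lower number from compound 1 to compound 3 (0.05 log units; within the scatter) in this series. Replacing pyrrolidin-1-yl with 2-(piperidin-1-yl)ethyl, which also lengthens the chain, gave a 2.7-fold lower number from compound 2 to compound 3 (0.44 log units; beyond the scatter) as a modest change. For the measured compounds named here, no measured compound carries methylpiperazine, so this guide is rough. The expected change is a 1.2-fold higher number from compound 3 to compound 4 (0.08 log units; within the scatter) and no step beyond the scatter is expected in this assay here. Compound 4 is expected at 180 nM within a range of 70 nM to 450 nM in this estimate.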

Compound 4, half-maximal inhibitory concentration: 330 nM
Beside the measured number, compound 4's estimate is 1.8-fold (0.26 log units) below it; the range from low to high includes it.
By their numbers in this assay, from the lowest: compounds 3, 1, 4 and 2 (each within the scatter of the next, the first and the last beyond it).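

In this assay, the longer chain ending in methylpiperazine gives the first step away from compound 3 that follows a change at this chain end on the longer side, with a 2.2-fold higher number from compound 3 to compound 4 (0.34 log units; beyond the scatter), so lengthening the chain and adding a second ring hetero atom together did not keep the number at the low end of the series. The other two comparisons are less clear: a 1.2-fold lower number from compound 2 to compound 4 (0.09 log units; within the scatter) and a 1.9-fold higher number from compound 1 to compound 4 (0.29 log units; within the scatter) both stay within the scatter, so compound 4 cannot be separated from either compound. No measurement shown accounts for the step from compound 3.

Chain length and end ring change together in compound 4, so their separate contributions remain open. Piperidin-1-yl on the chain of compound 4, or 4-methylpiperazin-1-yl on the chain of compound 3, would separate them, and a morpholine ring at the chain end is also untested here.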